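The source may hold more compounds than are shown below. What is called first, only, known or untested is meant among the compounds shown, and "the series" means these compounds.

Two compounds of this series have numbers in a functional assay on cells (Cancer cell lines, Homo sapiens) for cytotoxicity, read by sulforhodamine B assay, with a stated time of 48 h; a lower number here means a stronger inhibitor of growth, a higher number a weaker inhibitor of growth. Compound 1 `COc1ccc(C2CC(c3ccccc3)=NN2C2=NC(=O)/C(=C3\C(=O)Nc4ccc(Br)cc43)S2)cc1` gives 360 nM. Among the compounds with values here, compound 2 `CN(C)c1ccc(C2CC(c3ccccc3)=NN2C2=NC(=O)/C(=C3\C(=O)Nc4ccccc43)S2)cc1` gives 18800 nM, the highest of the two numbers and beyond the scatter from compound 1; the two differ in two places, so no single step joins them.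

Compound 3 `CN(C)c1ccc(C2CC(c3ccccc3)=NN2C2=NC(=O)/C(=C3\C(=O)Nc4ccc(Br)cc43)S2)cc1` differs from compound 2 by bromo in place of hydrogen on an aromatic carbon. Within the data shown here, no measured pair shows this step on its own. Compound 3 is expected to fall below compound 2, with the step from compound 2 to compound 3 in this assay estimated as a 6.3-fold lower number from compound 2 to compound 3 (0.80 log units; beyond the scatter). Compound 3 is thus estimated at 3000 nM in this assay, within 600 nM to 15000 nM.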

Compound 3, concentration for total growth inhibition: 450 nM
Estimate against measurement, compound 3: 6.7-fold (0.82 log units) above; the measured number lies below the stated range.
By their numbers in this assay, from the lowest: compounds 1 and 3 (each within the scatter of the next); then compound 2.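

In this assay, bromo in place of hydrogen on the aromatic carbon of the fused system gives a large gain on its own (a 42-fold lower number from compound 2 to compound 3 (1.62 log units; beyond the scatter)). With bromo present, dimethylamino in place of methoxy stays within the scatter (a 1.3-fold higher number from compound 1 to compound 3 (0.10 log units; within the scatter)), so in this pair the aryl substituent barely registers. The compounds shown offer no measurement that would explain the bromo step.

Going by these compounds, whether the bromo step holds with methoxy in place of dimethylamino remains open. So does whether chloro, fluoro or an amine on the same carbon would match bromo.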